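Methyl on the Ring Carbon, Tried on a Second Core

The source may hold more compounds than are shown below. What is called first, only, known or untested is meant among the compounds shown, and "the series" means these compounds.

Compound 3 `N/C(=N\NC(=S)N1CCSCC1)c1ccccn1` and compound 2 `Cc1cccc(/C(N)=N/NC(=S)N2CCSCC2)n1` share one core and differ in a single place: methyl in place of hydrogen on an aromatic carbon. In a functional assay on A-431 cells (Homo sapiens) for cytotoxicity, read by MTT assay, with a stated time of 72 h, tested at 30 uM (a higher number here means more inhibition of growth at the concentration tested, a lower number less inhibition of growth), compound 3 gives 81.3%, and compound 2 gives 64.5%, so this change made a number 16.8 percentage points lower from compound 3 to compound 2 (beyond the scatter). Compound 1 `N/C(=N\NC(=S)N1CCCCCC1)c1ccccn1` carries a different core; the difference between the two cores is not broken down here. In this assay compound 1 gives 72.3%. Compound 4 `Cc1cccc(/C(N)=N/NC(=S)N2CCCCCC2)n1` has not yet been measured. It differs from compound 1 by methyl in place of hydrogen on an aromatic carbon, the same change in the same place as before, now on the core of compound 1. Since the earlier change made a number 16.8 percentage points lower from compound 3 to compound 2 (beyond the scatter), a step of similar size is expected here: a number 16.8 percentage points lower from compound 1 to compound 4 (beyond the scatter). Compound 4 is therefore estimated to give 55.5% in this assay, most likely between 43% and 68%.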

Compound 4, percent growth inhibition at one concentration: 63.5%
Compound 4: middle estimate off by 8 percentage points, on the low side; measured number inside the range.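

In this assay, methyl in place of hydrogen on the core of compound 1 makes a number 8.8 percentage points lower from compound 1 to compound 4 (within the scatter). The two steps cannot be told apart, so the two cores show no measurable difference in how they take this change: the same change on two cores in this assay, a number 16.8 percentage points lower (beyond the scatter) from compound 3 to compound 2 and a number 8.8 percentage points lower (within the scatter) from compound 1 to compound 4, 8 percentage points apart, within the scatter of two such steps. This rests on just two pairs of compounds, tested in one cell line at one concentration, so it sets no rule for other cores, and the step on the core of compound 1 cannot on its own be told from ordinary scatter.

On these data alone, whether an ethyl group, a methoxy group or a chlorine atom in the same place would behave like methyl stays open. So does the effect of methyl on another carbon of the ring.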